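Compound 3 and a benzofuran swap at the chain carbon

This account rests on a few compounds, and the source may have more. Where it says the series, first, only, none or still open, it means among the compounds named here.

Compound 1 `O=c1[nH]/c(=C\c2ccccn2)c(=O)[nH]/c1=C\c1cccc(Oc2ccc(F)cc2)c1`: 49.1 nM
Compound 2 `O=c1[nH]/c(=C\c2ccc(Cl)o2)c(=O)[nH]/c1=C\c1cccc(Oc2ccc(F)cc2)c1`: 180 nM

Both values come from a functional assay on NCI-H460 cells (Homo sapiens) for cytotoxicity, read by MTT assay, with a stated time of 72 h; on this read-out higher numbers stand for weaker inhibition and lower numbers for stronger inhibition. Of the two numbers, compound 2 holds the higher at 180 nM, and the other compound lies below it by more than the scatter.

Compound 3 `O=c1[nH]/c(=C\c2cc3ccccc3o2)c(=O)[nH]/c1=C\c1cccc(Oc2ccc(F)cc2)c1` changes compound 2 in one place, on a double-bonded chain carbon bound to an aromatic carbon, where 1-benzofuran-2-yl stands in place of 5-chlorofuran-2-yl (1-benzofuran-2-yl in place of 5-chlorofuran-2-yl on a double-bonded chain carbon bound to an aromatic carbon). Both groups carry a five-membered aromatic ring with 1 hetero atom, and the entering group adds a six-membered aromatic ring of carbon only.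

For the measured compounds named here, one measured step bears on this place, the modest 3.7-fold higher number from compound 1 to compound 2 (0.56 log units; beyond the scatter), which replaced pyridin-2-yl with 5-chlorofuran-2-yl. Going by the values given here, no measured compound yet carries 1-benzofuran-2-yl, so the direction is poorly defined. A change no larger than that modest step is expected, with no clear shift beyond the scatter. The expected step is a 1.2-fold lower number from compound 2 to compound 3 (0.08 log units; within the scatter). For compound 3 the estimated value in this assay is 150 nM, with an expected range from 50 nM to 450 nM.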

Compound 3, half-maximal inhibitory concentration: 347 nM
Estimate against measurement, compound 3: 2.3-fold (0.36 log units) below, and the stated range covers the measured number.
By their numbers in this assay, from the lowest: compound 1; then compounds 2 and 3 (each within the scatter of the next).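

In this assay, 1-benzofuran-2-yl in place of 5-chlorofuran-2-yl on a double-bonded chain carbon bound to an aromatic carbon gives a 1.9-fold higher number from compound 2 to compound 3 (0.29 log units; within the scatter), so the added six-membered aromatic ring of carbon only does not separate compound 3 from compound 2 on this read-out. Measured against pyridin-2-yl, the same group gives a 7.1-fold higher number from compound 1 to compound 3 (0.85 log units; beyond the scatter), and compound 1 now holds a lower number than both compounds that carry a five-membered aromatic ring with 1 hetero atom at this place, with none of the three going against that order. Nothing measured here accounts for these numbers, so the result stands without an explanation.

The compounds shown leave open whether the lower number of compound 1 belongs to pyridin-2-yl itself or to six-membered aromatic rings more widely, a question that a plain phenyl or a pyridin-3-yl group at this place would address. They also leave open whether the order among these three groups would hold if the group on the other side of the shared core, identical in all three, gave way to a simple methoxy group.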